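A few compounds are considered here, and "the series" means these few. Any claim that something is new, unique, unknown or untested is made for them only; others in the source may bear on it.

Measured so far:
compound 1, `N#CC1CN1C(=O)Nc1ccc(F)cc1` — 2700 nM
compound 2, `CC(C)(C)NC(=O)N1CC1C#N` — 120000 nM

The account follows the step from compound 1 to compound 3. In a functional assay on MCF7 cells (Homo sapiens) for inhibition (a lower number here means a stronger inhibitor, a higher number a weaker inhibitor), compound 1 gives 2700 nM, the lowest of the two numbers at hand. For the measured compounds named here, its nearest neighbour is compound 2, which in this assay gives 120000 nM, a far higher number; the gap between the two lies well beyond the scatter, and no single-point step between them is recorded, so only the two values themselves speak.

Compound 3, `CCOC(=O)c1ccc(NC(=O)N2CC2C#N)cc1`, has not yet been measured in this assay. Compared with compound 1 the change is ethoxycarbonyl in place of fluoro on an aromatic carbon — ethoxycarbonyl in place of fluoro on an aromatic carbon. Going by the values given here, no measured pair shows this exchange, so the size of the step is open. Judged from compound 1 and its value of 2700 nM, the step from compound 1 to compound 3 is expected to be a 1.8-fold lower number from compound 1 to compound 3 (0.26 log units; within the scatter), a modest move toward a lower number that may not clear the scatter. Compound 3 is therefore estimated at 1500 nM, with a range from 300 nM to 8000 nM.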

Compound 3, half-maximal inhibitory concentration: 3300 nM
For compound 3 the middle estimate is 2.2-fold (0.34 log units) below the measured one; measured number inside the range.
By their numbers in this assay, from the lowest: compounds 1 and 3 (each within the scatter of the next); then compound 2.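

In this assay, putting ethoxycarbonyl in place of fluoro on the aromatic carbon gives a 1.2-fold higher number from compound 1 to compound 3 (0.09 log units; within the scatter), so the two compounds cannot be told apart in this assay. For the compounds shown here, the earlier compounds offered no single-place step, and this one is the first sign that this position, para to a group of 8 heavy atoms, accepts a substituent of 5 heavy atoms with hydrogen-bond acceptors in place of a single fluorine while the value stays within the scatter. No measurement of any property of these two groups bears on this result.

From the compounds shown here alone, the step is a single exchange at a single position, so it remains open whether a carboxylic acid, an amine or a longer chain at this aromatic carbon would also stay within the scatter of compound 1. Going by these compounds, it also remains open whether the ethyl part of the ethoxycarbonyl group matters at all, which a methyl ester or a plain hydrogen at the same place could begin to show.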